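The compounds below may be only part of what the source reports. "The series", "measured", "known", "first", "only" and "open" are said of these compounds alone.

Two compounds here carry measured numbers. Compound 1 `COc1ccc(Nc2nc(Oc3cccc(NC(=O)C=C(C)C)c3)c3sccc3n2)cc1` gives 28800 nM in a functional assay on HeLa cells (Homo sapiens) for inhibition, read by MTT assay, with a stated time of 72 h; on this read-out lower numbers stand for stronger inhibition and higher numbers for weaker inhibition. Within the data shown here, compound 2 `C/C=C/C(=O)Nc1cccc(Oc2nc(Nc3cccc(OC)c3)nc3ccsc23)c1` gives 20100 nM in this assay, a number that sits within the scatter of the one for compound 1, so the two cannot be ranked. Compound 3 `CC/C=C/C(=O)Nc1cccc(Oc2nc(Nc3cccc(OC)c3)nc3ccsc23)c1` has not been measured. It differs from compound 2 by methyl in place of hydrogen on a saturated chain carbon bound to a double-bonded chain carbon. Among the measured compounds shown here, no measured pair shows this change, so the expectation is a small step in this assay, none beyond the scatter, in no set direction. The expected step reads a 1.1-fold lower number from compound 2 to compound 3 (0.05 log units; within the scatter). Compound 3 is estimated at 18000 nM, within a range from 7000 nM to 50000 nM.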

Compound 3, half-maximal inhibitory concentration: 29400 nM
Compound 3: the middle estimate sits 1.6-fold (0.21 log units) below what was measured, within the range that was stated.
By their numbers in this assay, from the lowest: compounds 2, 1 and 3 (each within the scatter of the next).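

In this assay methyl in place of hydrogen on a saturated chain carbon bound to a double-bonded chain carbon gives a 1.5-fold higher number from compound 2 to compound 3 (0.17 log units; within the scatter) and stays within the scatter. Among these compounds, this is the first reading at this position: (prop-1-en-1-yl)carbonyl to (but-1-en-1-yl)carbonyl leaves no step that can be told from the scatter. No evidence at hand bears on this result.

Going by these compounds, whether a longer chain, an amine or a carboxylic acid on this chain would give a number beyond the scatter remains open. All three numbers here lie within the scatter of the next, so they set no order.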